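Enlarging the ether on a pyridine agonist of alpha3/beta4

A few compounds are considered here, and "the series" means these few. Any claim that something is new, unique, unknown or untested is made for them only; others in the source may bear on it.

Measured so far:
Compound 1, `COc1cncc(C2=CC3CC(C2)CN(C)C3)c1`, gives 3640 nM in an in vitro functional assay on SH-SY5Y cells for agonist activity at Neuronal acetylcholine receptor; alpha3/beta4 (Homo sapiens), read by FLIPR and calcium flux; a higher number here means that more compound is needed for the effect, a lower number that less compound is needed.
Compound 2, `C1=C(c2ccc(-c3ccccc3)nc2)CC2CNCC1C2`, gives 10900 nM in this assay.

Of the two numbers, compound 1 has the lower one, and compound 2 with its 10900 nM lies above it by more than the usual scatter, so compound 1 is the one that needs less material to trigger the cells. Compound 2 differs in several places at once, so its number says little about any single change.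

Compound 3, `CC(C)Oc1cncc(C2=CC3CC(C2)CN(C)C3)c1`, has not yet been run in this assay. It differs from compound 1 in exactly one place: isopropyl in place of methyl on an oxygen on an aromatic ring. Among the compounds with values here, no pair among the measured compounds shows what this kind of enlargement does, so there is no direct guide to the size or direction of the step. A bulkier alkyl on the oxygen is expected to leave the number in the same region or nudge it upward; the step of a 1.4-fold higher number from compound 1 to compound 3 (0.14 log units; within the scatter) is therefore estimated as small. On that basis compound 3 is expected to give about 5000 nM, most likely between 1500 nM and 16000 nM.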

Compound 3, half-maximal effective concentration: > 10000 nM
Compound 3 ended at the assay's limit; the forecaster's own chance of this, stated with the estimate: 15%; middle value at least 2.0-fold (0.30 log units) from the limit.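

The opening pair gave no view of this position, but the step from methoxy to isopropoxy now gives one: isopropyl in place of methyl on an oxygen on an aromatic ring produces an at least 2.7-fold higher number from compound 1 to compound 3 (0.43 log units; beyond the scatter). So, in this assay, this single change in the ether moves the result by more than ordinary repeat-to-repeat variation, and the direction is toward needing more compound. Compound 3 reads > 10000 nM, which is a limit of the assay and not a number, and the step is only a minimum because its true size stays hidden behind that limit: the limit of > 10000 nM in this assay, at which 1 of the 3 values shown sits.

With only methyl and isopropyl on this oxygen, one pair cannot show whether the number climbs gradually with each added carbon or jumps sharply somewhere along the way. An ethyl on the same oxygen would help to settle that. Compound 1 gives 3640 nM, and a hydroxyl or an amine in place of the ether would test whether anything at this position can bring the number lower than that.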